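A few compounds are considered here, and "the series" means these few. Any claim that something is new, unique, unknown or untested is made for them only; others in the source may bear on it.

Working notes on the series: in an ADME assay on J774.A1 cells (Mus musculus) for cytotoxicity, read by MTT assay, with a stated time of 72 h (a higher number here means that more compound is tolerated, a lower number that less compound is tolerated), compound 1 `COC(=O)C1=C(C)N(c2ccc(OC)cc2)C(C)=C(C(=O)OC)C1[C@@H]1O[C@H]2OC(C)(C)O[C@H]2[C@@H]1OCc1ccccc1` gives 14.1 ug/mL and compound 2 `COC(=O)C1=C(C)N(c2ccc(Cl)cc2)C(C)=C(C(=O)OC)C1[C@@H]1O[C@H]2OC(C)(C)O[C@H]2[C@@H]1OCc1ccccc1` gives 4.22 ug/mL, the lower of the two numbers. Compound 3 `COC(=O)C1=C(C)N(c2ccc(C)cc2)C(C)=C(C(=O)OC)C1[C@@H]1O[C@H]2OC(C)(C)O[C@H]2[C@@H]1OCc1ccccc1` differs from compound 2 by methyl in place of chloro on an aromatic carbon. Going by the values given here, one measured step bears on this change: a 3.3-fold lower number from compound 1 to compound 2 (0.52 log units; beyond the scatter), a modest step with chloro in place of methoxy. Removing that chloro is expected to give a partial return towards compound 1 in this assay. The estimated step is a 1.9-fold higher number from compound 2 to compound 3 (0.28 log units; within the scatter), upward and smaller than the measured one. For compound 3 the expected value is 8 ug/mL, with an estimated range of 3.5 ug/mL to 18 ug/mL.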

Compound 3, half-maximal cytotoxic concentration: 7.66 ug/mL
Beside the measured number, compound 3's estimate is 1.0-fold (0.02 log units) above it; low and high end bracket the measured number.
By their numbers in this assay, from the lowest: compounds 2, 3 and 1 (each within the scatter of the next, the first and the last beyond it).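

In this assay, the 4-chlorophenyl to 4-methylphenyl change gives a 1.8-fold higher number from compound 2 to compound 3 (0.26 log units; within the scatter), so these two groups are not separated at this position. The methyl and methoxy groups are not separated either, with a 1.8-fold lower number from compound 1 to compound 3 (0.26 log units; within the scatter), so of the three compounds only compound 1 and compound 2 lie beyond the scatter of each other. No measurement at hand offers a reason for these numbers. Still open, on these data alone, is whether an amine, a carboxylic acid or a longer chain at this position would stand beyond the scatter of all three compounds.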